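The compounds below may be only part of what the source reports. "The series", "measured", "known", "first", "only" and "open" are said of these compounds alone.

Compound 1, `Cn1c(=O)c(S(=O)(=O)c2ccc(F)cc2F)cc2cnc(Nc3ccc4cc[nH]c4c3)nc21`: 5000 nM
Compound 2, `Cn1c(=O)c(S(=O)(=O)c2ccc(F)cc2F)cc2cnc(Nc3ccc4[nH]c(C(=O)O)cc4c3)nc21`: 10000 nM
Compound 3, `Cn1c(=O)c(S(=O)(=O)c2ccc(F)cc2F)cc2cnc(Nc3ccccn3)nc21`: 75000 nM

These three compounds share one core and differ only in the group attached to a nitrogen on an aromatic ring. In a functional assay on DU-145 cells (Homo sapiens) for inhibition, read by trypan blue exclusion, with a stated time of 72 h (a lower number here means a stronger inhibitor, a higher number a weaker inhibitor), compound 3 gives the highest number of the three: the step of a 15-fold higher number from compound 1 to compound 3 (1.18 log units; beyond the scatter) is large, and the step of a 7.5-fold higher number from compound 2 to compound 3 (0.88 log units; beyond the scatter) is modest, both beyond the scatter, so compound 3 is the weakest inhibitor among those measured.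

Compound 4, `Cn1c(=O)c(S(=O)(=O)c2ccc(F)cc2F)cc2cnc(Nc3ccncn3)nc21`, has not yet been measured. It is compound 3 with pyrimidin-4-yl in place of pyridin-2-yl on a nitrogen on an aromatic ring; the pyrimidin-4-yl that enters carries one more ring nitrogen than the pyridin-2-yl that leaves.

The measured steps that bear on this position are a 15-fold higher number from compound 1 to compound 3 (1.18 log units; beyond the scatter) and a 7.5-fold higher number from compound 2 to compound 3 (0.88 log units; beyond the scatter), both replacing a bicyclic group by pyridin-2-yl. Among the compounds with values here, no measured step exchanges one six-membered ring for another, so the effect of adding a ring nitrogen here is untested. Compound 4 keeps a single small six-membered ring, as in compound 3, so the expected step of no change at the digits printed from compound 3 to compound 4 (within the scatter) in this assay is not beyond the scatter, in either direction. The estimate for compound 4 is therefore 75000 nM, with a range from 25000 nM to 200000 nM.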

Compound 4, half-maximal inhibitory concentration: 50000 nM
Compound 4: the middle estimate sits 1.5-fold (0.18 log units) above what was measured, and the stated range covers the measured number.
By their numbers in this assay, from the lowest: compounds 1 and 2 (each within the scatter of the next); then compounds 4 and 3 (each within the scatter of the next).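

In this assay, pyrimidin-4-yl in place of pyridin-2-yl on this nitrogen gives a 1.5-fold lower number from compound 3 to compound 4 (0.18 log units; within the scatter), so this first exchange of one six-membered aromatic ring for another cannot be told apart from no effect. Within the data shown here, the gap to the bicyclic groups also holds for a second single ring: replacing 2-carboxy-1H-indol-5-yl with pyrimidin-4-yl gives a 5.0-fold higher number from compound 2 to compound 4 (0.70 log units; beyond the scatter), and replacing 1H-indol-6-yl with it gives a 10-fold higher number from compound 1 to compound 4 (1.00 log units; beyond the scatter), both beyond the scatter, just as the earlier steps to compound 3 were. Nothing measured here explains why the bicyclic groups give the lower numbers or why the two single rings fall within the scatter of each other.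

The compounds shown leave open whether a phenyl ring, with no ring nitrogen at all, would match compound 3 and compound 4, and whether an amine or a short chain added to the single ring would bring the numbers closer to those of compound 1 and compound 2. They also leave open whether the ring size alone sets this gap, since each step from a bicyclic group to a single ring changes the whole group at once.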